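The source may hold more compounds than are shown below. What is called first, only, known or untested is meant among the compounds shown, and "the series" means these compounds.

Compound 1, `N#Cc1ccc(Nc2nc(Oc3ccnc4ccccc34)nc(N3CCN(c4ccc(F)cc4)CC3)n2)cc1C(F)(F)F`: in a functional assay on DU-145 cells (Homo sapiens) for cytotoxicity, read by sulforhodamine B assay, with a stated time of 48 h (on this read-out higher numbers stand for lower toxicity in this test and lower numbers for higher toxicity in this test), compound 1 gives > 100000 nM, which is a limit of the assay rather than a number.
Compound 2, `CC(=O)N1CCN(c2nc(Nc3ccc(C#N)c(C(F)(F)F)c3)nc(Oc3ccnc4ccccc34)n2)CC1`: in this assay compound 2 gives > 100000 nM, again a limit.
Compound 3, `CN1CCN(c2nc(Nc3ccc(C#N)c(C(F)(F)F)c3)nc(Oc3ccnc4ccccc34)n2)CC1`: in this assay compound 3 gives > 100000 nM, also a limit.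

Compound 3 therefore stands at the limit, the same place as the other two values shown, which is the limit of > 100000 nM in this assay, at which 3 of the 3 values shown sit. The step from compound 3 to compound 4, `N#Cc1ccc(Nc2nc(Oc3ccnc4ccccc34)nc(N3CCN(c4cccc(C(F)(F)F)c4)CC3)n2)cc1C(F)(F)F`, is 3-(trifluoromethyl)phenyl in place of methyl on an amine nitrogen in a ring. The measured steps that bear on it all change the group on that same ring nitrogen: a step that the two limits leave unreadable from compound 1 to compound 2, a step that the two limits leave unreadable from compound 1 to compound 3 and a step that the two limits leave unreadable from compound 2 to compound 3. None of them can be read, since both ends of each sit at the limit. Among the measured compounds shown here, the only reading the numbers allow is that exchanging 4-fluorophenyl, acetyl and methyl on that nitrogen left every compound at the limit. On that basis compound 4 is expected to stay at the limit as well, and the step that the limit leaves unreadable from compound 3 to compound 4 is estimated to be none beyond the scatter, though no readable step exists to check its size against. Compound 4 is estimated at 150000 nM, with a range from 40000 nM to 600000 nM, and is most likely to be reported only as a limit.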

Compound 4, concentration lethal to 50% of the cells: > 100000 nM
Compound 4: only a limit was reported (the forecaster's own chance of this, stated with the estimate: 75%); the middle value does not contradict the limit.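

Compound 4 gives > 100000 nM in this assay, again a limit. Its steps from compound 1, compound 2 and compound 3 cannot be read, since all four compounds sit at the same limit: the limit of > 100000 nM in this assay, at which 4 of the 4 values shown sit.

The compounds shown leave open whether any group on that ring nitrogen, or any change elsewhere on the shared core, would give a readable value in this assay.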